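The compounds below may be only part of what the source reports. "The series", "measured", "known", "first", "only" and "open" are said of these compounds alone.

The series centres on a shared core carrying an acetyl group and methoxy groups. Compound 1 `COc1cc(O)c2c(c1C(C)=O)OC(C)(C)C=C2` gives 0.0182 ug/mL in an ADME assay on cells (Erythrocyte, Homo sapiens), read by spectrophotometry and hemolysis; on this read-out lower numbers stand for stronger inhibition and higher numbers for weaker inhibition. Compound 2 `COc1cc2c(c(OC)c1C(C)=O)[C@H](O)[C@H](O)C(C)(C)O2` gives 1 ug/mL in this assay. Compound 3 `COc1cc(OC)c2c(c1C(C)=O)OC(C)(C)[C@@H](O)[C@H]2O` gives 0.0094 ug/mL in this assay, the lowest of the three numbers; against compound 1 the gap lies within the usual scatter, so the two cannot be ordered, whereas against compound 2 the gap is large and clearly beyond it.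

Compound 4 `COc1cc(OC)c2c(c1C(C)=O)OC(C)(C)[C@H](O)[C@@H]2O` has not yet been measured in this assay. It is related to compound 3 as follows: the two compounds have the same atoms and bonds and differ only in configuration as drawn: 2 of 2 stereo elements differ (all stereocentres are inverted: mirror images); a stereocentre at a saturated ring carbon is drawn S in compound 3 and R in compound 4; a stereocentre at a saturated ring carbon is drawn S in compound 3 and R in compound 4. For the measured compounds named here, nothing among the measured compounds shows how inverting all stereocentres acts in this assay; no single-change step is available here. In this setting the step from compound 3 to compound 4 is expected to be small, a 1.3-fold higher number from compound 3 to compound 4 (0.11 log units; within the scatter), in no particular direction and not beyond the scatter. Compound 4 is therefore estimated at 0.012 ug/mL, with a range from 0.003 ug/mL to 0.05 ug/mL.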

Compound 4, half-maximal inhibitory concentration: 0.88 ug/mL
Estimate against measurement, compound 4: 73-fold (1.87 log units) below; the whole stated range lies below it.
By their numbers in this assay, from the lowest: compounds 3 and 1 (each within the scatter of the next); then compounds 4 and 2 (each within the scatter of the next).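

In this assay inverting both stereocentres gives a 94-fold higher number from compound 3 to compound 4 (1.97 log units; beyond the scatter), so the read-out here depends on the configuration at the two saturated ring carbons and not only on which atoms and bonds are present. The earlier compounds shown here could not show this, as no two of them formed a pair differing in one place. This mirror-image pair gives the first such comparison, and the step can be put down to configuration alone because nothing else separates the two: the fact that compounds 3 and 4 differ only in the configuration as drawn

The compounds shown leave open which of the two stereocentres accounts for the step, as both are inverted together in this pair. They also leave open whether an amine or a methyl ether in place of the hydroxyl groups on those ring carbons would keep the number of compound 3.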